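The source may report more compounds than this note shows. Statements on the series, on what has been measured and on what is new or still open speak of the compounds shown alone.

Compound 1 `CSCC/C=N/NC(=O)c1cnc2c(C(F)(F)F)cccc2c1N[C@@H](CSc1ccccc1)CC(=O)N(C)C`: "not determined" (no result reported) in an ADME assay on Vero cells (Chlorocebus sabaeus) for cytotoxicity, read by MTT assay, with a stated time of 72 h; a lower number here means a stronger inhibitor, a higher number a weaker inhibitor
Compound 2 `CN(C)C(=O)C[C@H](CSc1ccccc1)Nc1c(C(=O)N/N=C/c2ccccc2F)cnc2ccc(F)cc12`: > 62.5 ug/mL in this assay
Compound 3 `COc1ccc(/C=N/NC(=O)c2cnc3ccc(F)cc3c2N[C@@H](CSc2ccccc2)CC(=O)N(C)C)cc1`: "not determined" (no result reported) in this assay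

Compound 3 stands without any number in this assay. Compound 1 likewise has no result reported there. Among the measured compounds shown here, the only reading among the three is that of compound 2, and it is a limit of the assay rather than a number, (the limit of > 62.5 ug/mL in this assay, at which 1 of the 3 values shown sits). For the measured compounds named here, no step between measured compounds can therefore be drawn.

Compound 4 `CN(C)C(=O)C[C@H](CSc1ccccc1)Nc1c(C(=O)N/N=C/c2ccc(F)cc2)cnc2ccc(F)cc12` differs from compound 3 by fluoro in place of methoxy on an aromatic carbon. With nothing measured on either side of this change, compound 4 is expected in this assay to sit where its measured relative sits, with no shift beyond the usual scatter. Compound 4 is accordingly estimated at 62.5 ug/mL, within 30 ug/mL to 100 ug/mL, a limit being the likeliest report.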

Compound 4, half-maximal inhibitory concentration: > 62.5 ug/mL
Compound 4 was reported as a limit; the forecaster's own chance of this, stated with the estimate: 80%; the middle value lies on the limit itself.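

No new step can be read between compound 2 and compound 4 in this assay, as both are reported only as the same assay limit: the limit of > 62.5 ug/mL in this assay, at which 2 of the 4 values shown sit. The compounds shown leave open whether 4-fluorophenyl and 2-fluorophenyl differ at all in this assay.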